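4-Chlorophenyl gives way to heptyl

The compounds below may be only part of what the source reports. "The series", "measured", "known", "first", "only" and "open" are said of these compounds alone.

Measured so far:
compound 1 `Oc1cccc(C(c2c[nH]c3ccc(Br)cc23)c2c[nH]c3ccc(Br)cc23)c1`: 2800 nM
compound 2 `O=[N+]([O-])c1ccc2[nH]cc(C(c3ccc(Cl)cc3)c3c[nH]c4ccc([N+](=O)[O-])cc34)c2c1`: > 100000 nM (a limit of the assay)

The measurements come from a functional assay on MCF7 cells (Homo sapiens) for inhibition, read by MTT assay, with a stated time of 48 h; a lower number here means a stronger inhibitor, a higher number a weaker inhibitor. In this assay compound 1 gives 2800 nM. Compound 2 stands only at a limit, > 100000 nM, and has no actual number. This is the limit of > 100000 nM in this assay, at which 1 of the 2 values shown sits.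

Compound 3 `CCCCCCCC(c1c[nH]c2ccc([N+](=O)[O-])cc12)c1c[nH]c2ccc([N+](=O)[O-])cc12` departs from compound 2 in one place: heptyl in place of 4-chlorophenyl on a saturated chain carbon bound to two aromatic carbons. It carries heptyl in place of 4-chlorophenyl, on a saturated chain carbon bound to two aromatic carbons.

Among the compounds with values here, no step between measured compounds offers a guide for this change, so the expectation is loose. The expected move an at least 2.5-fold lower number from compound 2 to compound 3 (0.39 log units; beyond the scatter) is a modest one towards stronger inhibition in this assay, and a reading at the same limit remains quite possible. The estimate for compound 3 is 40000 nM, with an expected range of 10000 nM to 100000 nM.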

Compound 3, half-maximal inhibitory concentration: 5800 nM
Compound 3: middle estimate off by 6.9-fold (0.84 log units), on the high side; measured number below the stated range.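

In this assay, heptyl in place of 4-chlorophenyl on a saturated chain carbon bound to two aromatic carbons gives an at least 17-fold lower number from compound 2 to compound 3 (1.23 log units; beyond the scatter). This shows that the group at this place, with the rest of the structure unchanged, can by itself move a compound from the limit to a measured number, and that a chain without a ring is accepted there. The value of compound 2, > 100000 nM, is a limit of the assay and not a number, so the step gives only a minimum size: the limit of > 100000 nM in this assay, at which 1 of the 3 values shown sits.

From the compounds shown here alone, it remains open whether a shorter chain, a longer chain such as decyl, or an unsubstituted phenyl at this place would give a similar number. Going by these compounds, it is also open whether heptyl would have a similar effect on the core of compound 1.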